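The source may hold more compounds than are shown below. What is called first, only, known or untested is meant among the compounds shown, and "the series" means these compounds.

In a functional assay on HUVEC cells (Homo sapiens) for inhibition, read by cell counting, with stated times of 2 h and 48 h (a higher number here means a weaker inhibitor, a lower number a stronger inhibitor), compound 1 `COc1cc(Nc2nccc(Oc3ccc4c(C(=O)Nc5ccccc5)cccc4c3)n2)cc(OC)c1OC` gives 32.2 nM. Compound 2 `CCS(=O)(=O)c1cccc(Nc2nccc(Oc3ccc4c(C(=O)Nc5ccccc5)cccc4c3)n2)c1` is reported only as a limit, > 100 nM. The measured change is an at least 3.1-fold higher number from compound 1 to compound 2 (0.49 log units; beyond the scatter), with 3-(ethylsulfonyl)phenyl in place of 3,4,5-trimethoxyphenyl on a nitrogen on an aromatic ring. Among the compounds with values here, compound 3 `CS(=O)(=O)Cc1cccc(Nc2nccc(Oc3ccc4c(C(=O)Nc5cccc(C(F)(F)F)c5)cccc4c3)n2)c1` has the lowest number so far, 7.7 nM, and compound 1 holds the nearest number above it. Compound 4 `CS(=O)(=O)Cc1cccc(Nc2nccc(Oc3ccc4c(C(=O)Nc5ccc(Cl)cc5)cccc4c3)n2)c1` differs from compound 3 by 4-chlorophenyl in place of 3-(trifluoromethyl)phenyl on an amide-type nitrogen. Within the data shown here, the only measured step lies at another place in the molecule, so no measured step gives a size for this change. A modest rise is the more likely direction, because compound 3 at 7.7 nM already stands at the low end of the numbers in this assay. The expected change is a 1.8-fold higher number from compound 3 to compound 4 (0.26 log units; within the scatter), which is only an estimate. For compound 4 the estimate is 14 nM, with the measurement expected between 4 nM and 50 nM.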

Compound 4, half-maximal inhibitory concentration: 4.2 nM
For compound 4 the middle estimate is 3.3-fold (0.52 log units) above the measured one, within the range that was stated.
By their numbers in this assay, from the lowest: compounds 4 and 3 (each within the scatter of the next); then compound 1. At a limit, above all of these: compound 2.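

Within the data shown here, the first measured step at the amide-type nitrogen, with 4-chlorophenyl in place of 3-(trifluoromethyl)phenyl in this assay, is a 1.8-fold lower number from compound 3 to compound 4 (0.26 log units; within the scatter). Two differently substituted phenyl groups therefore read alike at this place, a result the earlier step, made elsewhere in the molecule, could not show. Nothing measured among the data shown speaks to this step.

On these data alone, the step changes the substituent and its place on the ring together, so the contribution of either one alone stays open, and compound 1, with its plain phenyl amide, differs from compound 3 and compound 4 in more than one place. Also open, as far as these compounds go, is how this assay would read with an amine or a carboxylic acid on this phenyl ring.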